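This account rests on a few compounds, and the source may have more. Where it says the series, first, only, none or still open, it means among the compounds named here.

Compound 1 `COc1ccc([C@]2(CO)NC[C@@H](O)[C@@H]2O)cc1` gives 0.2% in an assay on isolated protein for inhibition of alpha-mannosidase (Canavalia ensiformis), tested at 1000 uM; on this read-out lower numbers stand for less inhibition and higher numbers for more inhibition at the one concentration tested (going by the name of the read-out).
Compound 2 `OC[C@@]1(c2cccc(F)c2)NC[C@@H](O)[C@@H]1O` gives 0% in this assay.
Compound 3 `COc1cccc([C@]2(CO)NC[C@@H](O)[C@@H]2O)c1` gives 0% in this assay.

All three compounds share one core and differ only in the group carried on the aromatic ring. Compound 3 stands level with compound 2 at the digits shown, and together they are the lowest of the three numbers; compound 1 is the furthest from compound 3, yet its number lies within the scatter. Within the data shown here, the one step between measured compounds is no change at the digits printed from compound 2 to compound 3 (within the scatter), a swap of methoxy in place of fluoro on an aromatic carbon that left the read-out unchanged.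

Compound 4 `COc1ccc([C@]2(CO)NC[C@@H](O)[C@@H]2O)cc1OC` is not yet measured. It differs from compound 3 by methoxy in place of hydrogen on an aromatic carbon. Among the measured compounds shown here, the only step that bears on this, the swap from compound 2 to compound 3, was flat, and no measured pair shows what a second methoxy on the ring does. Compound 4 is therefore expected to stay where compound 3 stands, with a number 1 percentage points higher from compound 3 to compound 4 (within the scatter) as the expected step. Compound 4 is estimated at 1%, with a range from 0% to 8%.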

Compound 4, a percentage reported as inhibition, at one concentration (the size of the read-out at that concentration, not a potency): 0%
Estimate against measurement, compound 4: 1 percentage points above; the range from low to high includes it.
By their numbers in this assay, from the lowest: compounds 2, 3, 4 and 1 (each within the scatter of the next).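

Placing a methoxy on this aromatic carbon, ortho to a methoxy group and para to a group of 9 heavy atoms, gives no change at the digits printed from compound 3 to compound 4 (within the scatter) in this assay, and adding the second methoxy to the other singly substituted ring gives a number 0.2 percentage points lower from compound 1 to compound 4 (within the scatter) on the same read-out. Among these compounds, these are the first steps that add a group to the ring rather than swap one for another, and both show that a ring with two methoxy groups reads no differently from a ring with one, with every number still close to nothing at the one concentration tested. Nothing here gives a reason for this flat result.

As far as these compounds go, whether an amine or a carboxylic acid at this position would move the number remains open. So does the effect of a longer chain, such as butoxy, in place of the methoxy.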